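The source may report more compounds than this note shows. Statements on the series, on what has been measured and on what is new or still open speak of the compounds shown alone.

In a functional assay on A549 cells (Homo sapiens) for antiproliferative activity, read by MTT assay, with a stated time of 48 h (a lower number here means a stronger inhibitor, a higher number a weaker inhibitor), compound 1 `COc1ccc(C(=O)c2ccc3c(c2)C=CC(C)(C)O3)c(NC(=O)CBr)c1` gives 1980 nM. That value lies within the scatter of compound 3 `CCNCC(=O)Nc1cc(OC)ccc1C(=O)c1ccc(OC)c2c1C=CC(C)(C)O2` at 2310 nM, whereas compound 2 `COc1ccc(C(=O)c2ccc(OC)c3c2C=CC(C)(C)O3)c(NC(=O)CO)c1` stands far lower at 100 nM. Compound 4 `CCNCC(=O)Nc1cc(OC)ccc1C(=O)c1ccc2c(c1)C=CC(C)(C)O2` keeps the core of compound 1 and alters only the end of the side chain: ethylamino in place of bromo on a saturated chain carbon bound to a carbonyl carbon. Ethylamino thus takes the place of bromo on a saturated chain carbon bound to a carbonyl carbon.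

Going by the values given here, no measured pair shows this exact exchange. The closest evidence is a 23-fold higher number from compound 2 to compound 3 (1.36 log units; beyond the scatter), a large step in which ethylamino replaces hydroxy. Its starting group is not bromo, however, so its size cannot simply be carried over. More useful is that compound 4 bears the same ethylamino group as compound 3, which has a slightly different core and gives 2310 nM, a value close to that of compound 1. Both ends of the comparison therefore sit at a similar level, and no step beyond the scatter is expected in this assay. Among the compounds with values here, the expected change is a 1.2-fold higher number from compound 1 to compound 4 (0.07 log units; within the scatter), though with only three measured compounds this remains uncertain. For compound 4 the estimated value is 2300 nM, with an expected range from 700 nM to 6500 nM.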

Compound 4, half-maximal inhibitory concentration: 1300 nM
Estimate against measurement, compound 4: 1.8-fold (0.25 log units) above; low and high end bracket the measured number.
By their numbers in this assay, from the lowest: compound 2; then compounds 4, 1 and 3 (each within the scatter of the next).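

Going by these compounds alone, this is the first direct reading of the exchange itself: in this assay, putting ethylamino in place of bromo on a saturated chain carbon bound to a carbonyl carbon gives a 1.5-fold lower number from compound 1 to compound 4 (0.18 log units; within the scatter), a step within the usual scatter. On the core of compound 1, then, the assay does not tell these two groups apart, even though ethylamino brings more heavy atoms and a hydrogen-bond donor that bromo lacks. The same ethylamino group gave a much larger step when it replaced hydroxy, a 23-fold higher number from compound 2 to compound 3 (1.36 log units; beyond the scatter), so the size of a step at this place depends at least on which group leaves, and in that pair the core also differs from that of compound 1. The data shown offer no measurement that could explain why bromo and ethylamino read alike here.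

On these data alone, it remains open whether hydroxy would also give a low number on the core of compound 1, which would show whether the large step carries over from one core to the other. As far as these compounds go, how a dimethylamino group, a longer alkylamino chain or a carboxylic acid would read at this place also remains unknown.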